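The source may hold more compounds than are shown below. What is called first, only, known or untested is meant among the compounds shown, and "the series" means these compounds.

Measured so far:
compound 1 `CC1=C(C(=O)OCc2ccccn2)C(c2ccc(Cl)cc2)C2=C(CCCC2=O)N1`: 2.24
compound 2 `CC1=C(C(=O)OCc2cccnc2)C(c2ccc(C#N)cc2)C2=C(CCCC2=O)N1`: 1.36

In a physicochemical assay for lipophilicity, measured as octanol-water partition (on this read-out lower numbers stand for lower lipophilicity and higher numbers for higher lipophilicity), compound 2 gives 1.36, the lower of the two numbers, while compound 1 gives 2.24, a gap beyond the usual scatter. Compound 3 `CC1=C(C(=O)OCc2cccnc2)C(c2cccs2)C2=C(CCCC2=O)N1` is not yet measured. It differs from compound 2 by one change: thiophen-2-yl in place of 4-cyanophenyl on a saturated ring carbon. Among the measured compounds shown here, no step between measured compounds matches this change, so the expectation rests on the two values alone. The expected step is a number 0.34 log units higher from compound 2 to compound 3 (beyond the scatter), a small rise in this assay, within or just beyond the scatter. Compound 3 is thus estimated at 1.7, with a range from 1.3 to 2.1.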

Compound 3, partition coefficient: 1.4
Compound 3: middle estimate off by 0.30 log units, on the high side; the measured number falls inside the stated range.
By their numbers in this assay, from the lowest: compounds 2 and 3 (each within the scatter of the next); then compound 1.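

In this assay, among the compounds shown here, thiophen-2-yl in place of 4-cyanophenyl on this saturated ring carbon gives a number 0.04 log units higher from compound 2 to compound 3 (within the scatter), the first single-place step at this position. Here, this read-out does not separate a five-membered aromatic ring with a sulfur atom from a six-membered carbon ring bearing a nitrile. Nothing available gives a reason for this. This single step leaves open whether other groups at this position, such as an amine or a carboxylic acid, would shift the number. It also leaves open whether this exchange reads the same with a different ester group.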